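Removing the fluorine from compound 1

This account rests on a few compounds, and the source may have more. Where it says the series, first, only, none or still open, it means among the compounds named here.

Compound 1 `COc1ccc(CNCc2c(-c3nnc(SC(C)C)n3-c3ccccc3)n(C)c3ccc(F)cc23)cc1` is the starting point. In a physicochemical assay for lipophilicity (on this read-out higher numbers stand for higher lipophilicity and lower numbers for lower lipophilicity), compound 1 gives 6.42, level with compound 2 `COc1cccc(CNCc2c(-c3nnc(SC(C)C)n3-c3ccccc3)n(C)c3ccc(F)cc23)c1`, which gives 6.42; the two stand together as the highest of the three measured numbers. Compound 3 `CC(C)Sc1nnc(-c2c(CNCC3CC3)c3cc(F)ccc3n2C)n1-c1ccccc1` gives 5.4. The measured steps all concern the group on the saturated chain carbon bound to the amine nitrogen: no change at the digits printed from compound 1 to compound 2 (within the scatter), whereas a number 1.02 log units lower from compound 1 to compound 3 (beyond the scatter) and a number 1.02 log units lower from compound 2 to compound 3 (beyond the scatter).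

Compound 4 `COc1ccc(CNCc2c(-c3nnc(SC(C)C)n3-c3ccccc3)n(C)c3ccccc23)cc1` differs from compound 1 elsewhere: hydrogen in place of fluoro on an aromatic carbon, the site being on an aromatic carbon of a six-membered aromatic ring of carbon only, part of a fused system of two rings, meta to a fused ring and para to a fused ring. Among the measured compounds shown here, none of the measured steps touches this part of the shared core, so they do not bear directly on the change; the loss of one heavy atom is expected to give a small step downward in this assay, within or just beyond the scatter. Compound 4 is therefore expected to show 6.27, between 5.9 and 6.6, meaning an estimated step of a number 0.15 log units lower from compound 1 to compound 4 (within the scatter).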

Compound 4, partition coefficient: 6.27
Compound 4: middle estimate and measured number agree at the digits printed; the measured number falls inside the stated range.
By their numbers in this assay, from the lowest: compound 3; then compounds 4, 1 and 2 (each within the scatter of the next).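

With hydrogen in place of fluoro on this aromatic carbon, this assay gives a number 0.15 log units lower from compound 1 to compound 4 (within the scatter) and so does not separate the two compounds. This is the first step shown at this part of the shared core, and it stands in contrast to the step on the saturated chain carbon bound to the amine nitrogen, which gives a number 1.02 log units lower from compound 1 to compound 3 (beyond the scatter). Nothing measured here offers an explanation for the size of the step at the aromatic carbon.

On these data alone, what chloro, methoxy or a carboxylic acid on this aromatic carbon would give in this assay remains open. As far as these compounds go, it is also open whether the same exchange of fluoro for hydrogen would give a similar step with cyclopropyl or 3-methoxyphenyl on the chain carbon in place of 4-methoxyphenyl.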